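This account rests on a few compounds, and the source may have more. Where it says the series, first, only, none or still open, it means among the compounds named here.

Measured so far:
Compound 1, `COc1ccc(-c2cc(/C=C/C(=O)c3ccc(N)cc3)[nH]n2)cc1`: -62%
Compound 2, `COc1cc(-c2cc(/C=C/C(=O)c3ccc(N)cc3)[nH]n2)cc(OC)c1OC`: -55%

Both were tested in a functional assay on NCI-H23 cells (Homo sapiens) for cytotoxicity, read by sulforhodamine B assay, with a stated time of 48 h, tested at 100 uM; a lower number here means a stronger effect, a higher number a weaker effect of the compound at the concentration tested. Of the two numbers, that of compound 2 is the one at the top, but compound 1 lies within the scatter of it, so the two cannot be told apart on these measurements.

Compound 3, `COc1ccc(C(=O)/C=C/c2cc(-c3cc(OC)c(OC)c(OC)c3)n[nH]2)cc1`, has not yet been measured. It differs from compound 2 in one place: methoxy in place of amino on an aromatic carbon. Among the measured compounds shown here, no measured pair shows this change, so nothing here says how this assay answers to it; the two measured compounds differ elsewhere and agree within the scatter. The expected step is a number 5 percentage points higher from compound 2 to compound 3 (within the scatter), not clearly beyond the scatter in either direction. Compound 3 is therefore estimated at -50%, with a range from -80% to -15%.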

Compound 3, a percentage reported as activity, at one concentration (the size of the read-out at that concentration, not a potency): -23%
The estimate for compound 3 lay 27 percentage points below the measured number; low and high end bracket the measured number.
By their numbers in this assay, from the lowest: compounds 1 and 2 (each within the scatter of the next); then compound 3.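

Replacing the 4-aminophenyl with a 4-methoxyphenyl, on an aromatic carbon para to a large group, gives in this assay a number 32 percentage points higher from compound 2 to compound 3 (beyond the scatter) and leaves the rest of the molecule unchanged. Compounds 1 and 2 both carry amino at this carbon, so they could not show that this position matters; compound 3 shows that it does, and that amino and methoxy are not interchangeable here. Nothing available explains why the two groups differ at this carbon.

Among the compounds shown here, with only two groups seen at this position, it remains open whether a hydroxyl group, a dimethylamino group or a plain hydrogen would behave more like amino or more like methoxy. As far as these compounds go, it also remains open whether the same swap would have a similar effect on compound 1.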